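The source may report more compounds than this note shows. Statements on the series, on what has been measured and on what is new or still open speak of the compounds shown alone.

Measured compounds:
- compound 1 `CCCCN1CCC(C(=O)Nc2cc(Cl)c(N)cc2OC)CC1`: > 10 mg/kg
- compound 2 `CCN1CCC(C(=O)Nc2cc(Cl)c(N)cc2OC)CC1`: > 10 mg/kg

In a functional assay on the whole organism for antagonist activity, with Mus musculus as the target (a lower number here means that less compound is needed, a higher number that more compound is needed for the effect), compound 1 gives > 10 mg/kg, a limit of the assay. In this assay compound 2 gives > 10 mg/kg, also a limit. The step that the two limits leave unreadable from compound 1 to compound 2 is therefore unreadable; both values sit at the limit of > 10 mg/kg in this assay, at which 2 of the 2 values shown sit. Compound 2 thus stands only at a limit, with no number of its own.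

Compound 3 `COc1cccc(CN2CCC(C(=O)Nc3cc(Cl)c(N)cc3OC)CC2)c1` differs from compound 2 by 3-methoxyphenyl in place of methyl on a saturated chain carbon bound to an amine nitrogen in a ring. Among the measured compounds shown here, no measured step bears on this change, and the single step available, a step that the two limits leave unreadable from compound 1 to compound 2, gives no size. Compound 3 is therefore expected at 15 mg/kg, range 3 mg/kg to 60 mg/kg. The expected step that the limit leaves unreadable from compound 2 to compound 3 is an estimate only, most likely ending again at a limit.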

Compound 3, dose for half-maximal effect: > 4 mg/kg
Compound 3 ended at the assay's limit (the forecaster's own chance of this, stated with the estimate: 70%); the middle value is on the limit's open side.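

In this assay compound 3 gives > 4 mg/kg, again a limit. No step can be read among compound 1, compound 2 and compound 3. Still open, on these data alone, is how far the butyl, ethyl and 3-methoxybenzyl compounds truly differ in this assay.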